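The source may hold more compounds than are shown below. What is called first, only, known or untested is meant among the compounds shown, and "the series" means these compounds.

In a functional assay on SGC-7901 cells (Homo sapiens) for cytotoxicity, read by MTT assay, with a stated time of 48 h (a higher number here means a weaker inhibitor, a lower number a stronger inhibitor), three compounds sharing a core and differing in the aromatic group on a sulfur have been measured. Compound 1 `CC1=NN(C(=O)CSc2ccccn2)[C@@H](c2cc(Br)cc(Br)c2O)C1` gives 10300 nM, compound 2 `CC1=NN(C(=O)CSc2ccccc2)[C@@H](c2cc(Br)cc(Br)c2O)C1` gives 24100 nM, and compound 3 `CC1=NN(C(=O)CSc2ccc(Br)cc2)[C@@H](c2cc(Br)cc(Br)c2O)C1` gives 8210 nM. Compound 3 sits in the lower part of this range. The measured step of a 1.3-fold lower number from compound 1 to compound 3 (0.10 log units; within the scatter) leaves it level, within the scatter, with its nearest neighbour, while a 2.9-fold lower number from compound 2 to compound 3 (0.47 log units; beyond the scatter) sets it apart from the remaining compound.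

Compound 4 `CC1=NN(C(=O)CSc2nc3ccccc3s2)[C@@H](c2cc(Br)cc(Br)c2O)C1` has yet to be measured. The structural change is 1,3-benzothiazol-2-yl in place of 4-bromophenyl on a sulfur, with 1,3-benzothiazol-2-yl in place of 4-bromophenyl on a sulfur. Among the compounds with values here, no measured compound carries this group, so the only guide is the other exchanges on the same sulfur. Besides the two steps above, these include a 2.3-fold higher number from compound 1 to compound 2 (0.37 log units; beyond the scatter). The largest of these steps is modest, and none of the three compounds stands far from the others. On these data alone, a change beyond the scatter is therefore not expected in this assay, and the direction remains open. The estimated step is a 1.1-fold higher number from compound 3 to compound 4 (0.04 log units; within the scatter). For compound 4 the expected value is 9000 nM, with an estimated range of 3500 nM to 20000 nM.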

Compound 4, half-maximal inhibitory concentration: 12300 nM
Beside the measured number, compound 4's estimate is 1.4-fold (0.14 log units) below it; low and high end bracket the measured number.
By their numbers in this assay, from the lowest: compounds 3, 1, 4 and 2 (each within the scatter of the next, the first and the last beyond it).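

In this assay the 1,3-benzothiazol-2-yl group, the only one here with a five-membered aromatic ring holding 2 hetero atoms, gives no step beyond the scatter against any of the three single-ring groups on this sulfur: a 1.5-fold higher number from compound 3 to compound 4 (0.18 log units; within the scatter), a 1.2-fold higher number from compound 1 to compound 4 (0.08 log units; within the scatter) and a 2.0-fold lower number from compound 2 to compound 4 (0.29 log units; within the scatter). Exchanging 4-bromophenyl, with 7 heavy atoms and 0 hydrogen-bond acceptors, for this group, with 9 heavy atoms and 2 hydrogen-bond acceptors, therefore leaves the number level, and compound 4 stands within the scatter of both compound 2 and compound 3 even though those two are set apart by a 2.9-fold lower number from compound 2 to compound 3 (0.47 log units; beyond the scatter). Nothing measured here accounts for why these groups give such similar numbers.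

Every group shown on this sulfur is aromatic, so it remains open whether a plain alkyl chain or a saturated ring such as piperidine would stay in the same range. On these data alone, it is also open whether an amine or a carboxylic acid on the aromatic ring would shift the number beyond the scatter.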